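This account rests on a few compounds, and the source may have more. Where it says the series, first, only, none or still open, it means among the compounds named here.

Of the compounds shown here, three have been tested in a functional assay on NCI-H460 cells (Homo sapiens) for inhibition, read by sulforhodamine B assay, with a stated time of 48 h; on this read-out lower numbers stand for stronger inhibition of growth and higher numbers for weaker inhibition of growth. Compound 1 `O=C1C=COC(/C=C/c2ccc(C(F)(F)F)cc2)C1` gives 95.6 uM in this assay. Compound 2 `COc1ccc(/C=C/C2CC(=O)C=CO2)cc1` differs from compound 1 in one place, (methoxy in place of trifluoromethyl on an aromatic carbon), and in this assay compound 2 gives 149 uM; the step is a 1.6-fold higher number from compound 1 to compound 2 (0.19 log units; within the scatter). Compound 3 `O=C1C=CCC(/C=C/c2ccc(C(F)(F)F)cc2)O1` is built from the same atoms as compound 1, joined differently; the difference between the two cores is not broken down here. In this assay compound 3 gives 477 uM, the highest of the three numbers and beyond the scatter from both of the others.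

Compound 4 `COc1ccc(/C=C/C2CC=CC(=O)O2)cc1` has not yet been measured. It stands to compound 3 as compound 2 stands to compound 1: the same change, (methoxy in place of trifluoromethyl on an aromatic carbon), at the same place. Going by the values given here, because the one measured instance of this change gave a 1.6-fold higher number from compound 1 to compound 2 (0.19 log units; within the scatter), a step of much the same size is expected the second time. The expected step is a 1.6-fold higher number from compound 3 to compound 4 (0.20 log units; within the scatter), resting on that single earlier step and on the value of compound 3, 477 uM. Compound 4 is thus expected to give about 760 uM in this assay, with a likely range from 350 uM to 1600 uM.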

Compound 4, concentration for growth inhibition (reported as GI): 28.3 uM
Compound 4: middle estimate off by 27-fold (1.43 log units), on the high side; measured number below the stated range.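

In this assay, methoxy in place of trifluoromethyl gives a 17-fold lower number from compound 3 to compound 4 (1.23 log units; beyond the scatter), a large step towards stronger inhibition of growth, while the same change on the other core gave a 1.6-fold higher number from compound 1 to compound 2 (0.19 log units; within the scatter). The size of this change therefore depends on the core it sits on, and a step measured on one core cannot simply be carried over to the other: the same change on two cores in this assay, a 1.6-fold higher number (0.19 log units; within the scatter) from compound 1 to compound 2 and a 17-fold lower number (1.23 log units; beyond the scatter) from compound 3 to compound 4, 26-fold (1.42 log units) apart, beyond the scatter of two such steps. This rests on one pair of compounds per core, so it shows that the two cores can respond differently, but it does not show why they do or give a rule for any other change.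

The four compounds carry only trifluoromethyl or methoxy, always at the same place on the aromatic ring. As far as these compounds go, it remains open how other groups, such as an amine or a carboxylic acid, would behave there on each core, and whether the two cores would again part ways.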